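The source may report more compounds than this note shows. Statements on the series, on what has been measured and on what is new or still open speak of the compounds shown alone.

Measured compounds:
- compound 1, `CCCN1CC[C@@]2(OC)OC(N)=C(C#N)[C@@H](c3ccccc3)[C@@H]2C1`: 20700 nM
- compound 2, `CCN1CC[C@@]2(OC)OC(N)=C(C#N)[C@@H](c3ccc(Br)cc3)[C@@H]2C1`: 13200 nM

Both numbers come from a functional assay on trachea (Cavia porcellus); on this read-out higher numbers stand for weaker inhibition and lower numbers for stronger inhibition. Compound 2 has the lower of the two numbers, but compound 1 sits close to it, within the scatter of this assay, so the two cannot be told apart on potency. The two compounds also differ in two places at once, the chain on the ring nitrogen and the halogen on the phenyl ring, so no single change can be read from their values.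

Compound 3, `CCCN1CC[C@@]2(OC)OC(N)=C(C#N)[C@@H](c3ccc(Br)cc3)[C@@H]2C1`, has not yet been measured in this assay. It follows from compound 2 by one change: methyl in place of hydrogen on a saturated chain carbon, two bonds along the chain from an amine nitrogen in a ring. Compound 1 already carries this propyl chain, and its number in this assay, 20700 nM, lies within the scatter of compound 2, which gives no sign that the longer chain moves the number far in either direction. The expected step is a 1.1-fold lower number from compound 2 to compound 3 (0.04 log units; within the scatter), no larger than the scatter. Compound 3 is therefore estimated at 12000 nM in this assay, with a likely range from 5000 nM to 30000 nM.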

Compound 3, half-maximal inhibitory concentration: 19400 nM
Beside the measured number, compound 3's estimate is 1.6-fold (0.21 log units) below it, and the stated range covers the measured number.
By their numbers in this assay, from the lowest: compounds 2, 3 and 1 (each within the scatter of the next).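

Among the compounds shown here, compound 3 makes two single changes readable for the first time, and neither can be told apart from the scatter. In this assay, with the bromo group held in place, the ethyl to propyl change, methyl in place of hydrogen on a saturated chain carbon two bonds along the chain from an amine nitrogen in a ring, gives a 1.5-fold higher number from compound 2 to compound 3 (0.17 log units; within the scatter). With the propyl chain held in place, bromo in place of hydrogen on an aromatic carbon gives a 1.1-fold lower number from compound 1 to compound 3 (0.03 log units; within the scatter), so at neither place does the change shift the number by more than repeated measurements might. No other measurement is available that bears on these two steps.

On these data alone, it remains open whether a longer chain such as butyl, or a benzyl group, on the same ring nitrogen would give a step beyond the scatter. The same question stands for a chloro or methoxy group on the aromatic carbon that carries the bromo group in compound 3.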